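A few compounds are considered here, and "the series" means these few. Any claim that something is new, unique, unknown or untested is made for them only; others in the source may bear on it.

Compound 1 `CCCCCC(CCO)n1cnc2c(NC)ncnc21`: > 50000 nM
Compound 2 `CCCCCC(CCO)n1cnc2c(N)ncnc21`: > 50000 nM
Compound 3 `CCCCCCCC(CCO)n1cnc2c(NC)ncnc21`: 12500 nM

All three were tested in a functional assay on HCT-116 cells (Homo sapiens) for antiproliferative activity, read by MTT assay, with a stated time of 48 h; on this read-out higher numbers stand for weaker inhibition and lower numbers for stronger inhibition. The value for compound 2 is a limit of the assay, not a number. The value for compound 1 is likewise a limit (the limit of > 50000 nM in this assay, at which 2 of the 3 values shown sit). Only compound 3 gives a number in this assay. The step from compound 2 to compound 1 is methyl in place of hydrogen on a nitrogen on an aromatic ring, and its size is a step that the two limits leave unreadable from compound 2 to compound 1. The step of an at least 4.0-fold lower number from compound 1 to compound 3 (0.60 log units; beyond the scatter) is read from compound 1 to compound 3. How the core of compound 3 differs from that of compound 2 is not broken down here.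

Compound 4 `CCCCCCCC(CCO)n1cnc2c(N(C)C)ncnc21` is not yet measured. It differs from compound 3 by methyl in place of hydrogen on a nitrogen on an aromatic ring. Going by the values given here, this is the same kind of change as the one from compound 2 to compound 1, but around the place the nitrogen also carries a saturated chain carbon besides the aromatic carbon. Since a step that the two limits leave unreadable from compound 2 to compound 1 left that earlier step unreadable, the size of the new step is uncertain; the step of a 1.6-fold higher number from compound 3 to compound 4 (0.20 log units; within the scatter) is only an expectation. Compound 4 is estimated at 20000 nM, between 5000 nM and 50000 nM.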

Compound 4, half-maximal inhibitory concentration: > 50000 nM
Compound 4: only a limit was reported; the forecaster's own chance of this, stated with the estimate: 40%; middle value at least 2.5-fold (0.39 log units) from the limit.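

In this assay compound 4 gives > 50000 nM, which is a limit of the assay and not a number. On compound 3, methyl in place of hydrogen on a nitrogen on an aromatic ring, here the change from methylamino to dimethylamino, gives an at least 4.0-fold higher number from compound 3 to compound 4 (0.60 log units; beyond the scatter), so this one change goes with weaker inhibition. This does not show that the change carries over from one core to another, since the step of the same kind from compound 2 to compound 1 cannot be read, and the new step has only a lower bound for its size: the limit of > 50000 nM in this assay, at which 3 of the 4 values shown sit.

The compounds shown leave open whether an amino group in place of methylamino on the core of compound 3 would give a readable number, which would allow a second step on that core to be sized. They also leave open whether an ethyl group on that nitrogen, or a longer chain on the core, would move the value away from that of compound 3 at 12500 nM.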